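From compound 3 to compound 4: a step without a size

This account rests on a few compounds, and the source may have more. Where it says the series, first, only, none or still open, it means among the compounds named here.

Compound 1 `COc1cc(/C=C(/SCc2ccc(Br)cc2)C(=O)c2ccc(C(=O)O)cc2)ccc1F`, compound 2 `O=C(O)c1ccc(C(=O)/C(=C\c2cc([N+](=O)[O-])ccc2F)SCc2ccc(Br)cc2)cc1` and compound 3 `O=C(O)c1ccc(C(=O)/C(=C\c2ccc(Cl)c([N+](=O)[O-])c2)SCc2ccc(Br)cc2)cc1` share one core. In a physicochemical assay for solubility (on this read-out higher numbers stand for higher solubility and lower numbers for lower solubility), compound 1 gives < 1000 ug/mL, which is a limit. In this assay compound 2 gives < 1000 ug/mL, also a limit. In this assay compound 3 gives < 1000 ug/mL, again a limit, so it has no number of its own. Among the measured compounds shown here, the series so far shows (the limit of < 1000 ug/mL in this assay, at which 3 of the 3 values shown sit).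

Compound 4 `O=C(O)c1ccc(C(=O)/C(=C\c2ccc(O)c(Br)c2)SCc2ccc(Br)cc2)cc1` arises through one change: 3-bromo-4-hydroxyphenyl in place of 4-chloro-3-nitrophenyl on a double-bonded chain carbon bound to a double-bonded chain carbon.

Three measured steps at the same place bear on it: a step that the two limits leave unreadable from compound 1 to compound 2, a step that the two limits leave unreadable from compound 1 to compound 3 and a step that the two limits leave unreadable from compound 2 to compound 3. None offers a size, so no step beyond the scatter and no direction is expected in this assay. The estimated step is a step that the limit leaves unreadable from compound 3 to compound 4. For compound 4 the estimate is 500 ug/mL, with an expected range of 100 ug/mL to 1000 ug/mL.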

Compound 4, solubility: < 1000 ug/mL
Compound 4: a limit, no number (the forecaster's own chance of this, stated with the estimate: 85%); the middle value lies beyond the limit too.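

In this assay, among the compounds shown here, compound 4 gives < 1000 ug/mL, a limit, so no step among compound 1, compound 2, compound 3 and compound 4 can be read. How far these compounds differ in this assay stays open, with every value resting on one limit: the limit of < 1000 ug/mL in this assay, at which 4 of the 4 values shown sit.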